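Replacing a dimethoxyphenyl by a dihydrobenzodioxinyl group

The compounds below may be only part of what the source reports. "The series", "measured", "known", "first", "only" and "open" are said of these compounds alone.

Three compounds share one core: a sulfonamide carrying two trifluoromethyl groups, joined through a chain to an amine nitrogen whose saturated chain carbon bears an aromatic group. Compound 1 `O=S(=O)(NCCCNCc1ccccc1Cl)c1cc(C(F)(F)F)cc(C(F)(F)F)c1` carries a 2-chlorophenyl group there, and in a functional assay on ASPC1 cells (Homo sapiens) for inhibition, read by MTT assay, with a stated time of 72 h (on this read-out lower numbers stand for stronger inhibition of growth and higher numbers for weaker inhibition of growth), compound 1 gives 13000 nM. Compound 2 `O=S(=O)(NCCCNCc1ccc(Cl)c(Cl)c1)c1cc(C(F)(F)F)cc(C(F)(F)F)c1` carries a 3,4-dichlorophenyl group, and in this assay compound 2 gives 2800 nM. Compound 3 `COc1ccc(CNCCCNS(=O)(=O)c2cc(C(F)(F)F)cc(C(F)(F)F)c2)cc1OC` carries a 3,4-dimethoxyphenyl group, and in this assay compound 3 gives 6400 nM, the second highest of the three numbers. The steps among them are all modest: a 4.6-fold lower number from compound 1 to compound 2 (0.67 log units; beyond the scatter), a 2.0-fold lower number from compound 1 to compound 3 (0.31 log units; beyond the scatter) and a 2.3-fold higher number from compound 2 to compound 3 (0.36 log units; beyond the scatter).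

Compound 4 `O=S(=O)(NCCCNCC1COc2ccccc2O1)c1cc(C(F)(F)F)cc(C(F)(F)F)c1` has not yet been measured. It differs from compound 3 in one place: 2,3-dihydro-1,4-benzodioxin-2-yl in place of 3,4-dimethoxyphenyl on a saturated chain carbon bound to an amine nitrogen. Among the measured compounds shown here, none of the measured steps makes this exact change; the nearest comparisons, the steps from compound 1 and compound 2 to compound 3, show only modest shifts when one aromatic group replaces another on that chain carbon. The step from compound 3 to compound 4 in this assay is therefore expected to be small, a 1.1-fold lower number from compound 3 to compound 4 (0.03 log units; within the scatter), with no clear direction beyond the scatter. Compound 4 is estimated to give 6000 nM in this assay, within a range from 2500 nM to 15000 nM.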

Compound 4, concentration for 50% growth inhibition: 2900 nM
Estimate against measurement, compound 4: 2.1-fold (0.32 log units) above; measured number inside the range.
By their numbers in this assay, from the lowest: compounds 2 and 4 (each within the scatter of the next); then compound 3; then compound 1.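

In this assay, the two groups match in their counts of heavy atoms, hydrogen-bond donors and hydrogen-bond acceptors, yet exchanging 3,4-dimethoxyphenyl for 2,3-dihydro-1,4-benzodioxin-2-yl gives a 2.2-fold lower number from compound 3 to compound 4 (0.34 log units; beyond the scatter), so this position responds to how those same kinds of atoms are arranged and not only to which atoms are present. A group with a non-aromatic ring on the chain carbon also matches the best of the phenyl groups shown, with a 1.0-fold higher number from compound 2 to compound 4 (0.02 log units; within the scatter), a difference within the scatter, and it gives a 4.5-fold lower number from compound 1 to compound 4 (0.65 log units; beyond the scatter), a step close in size to a 4.6-fold lower number from compound 1 to compound 2 (0.67 log units; beyond the scatter). Nothing available explains why the new group gives a lower number than the 3,4-dimethoxyphenyl group.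

The compounds shown leave open how an unsubstituted phenyl group, a pyridine ring or a saturated cyclohexyl group would behave on this chain carbon, and whether a longer chain between the two nitrogens would shift these numbers. They also leave open whether the two mirror-image forms of the 2,3-dihydro-1,4-benzodioxin-2-yl group give the same number.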